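The source may report more compounds than this note shows. Statements on the series, on what has been measured and on what is new or still open speak of the compounds shown alone.

Values measured so far in a physicochemical assay for solubility (a higher number here means a more soluble compound, a lower number a less soluble compound), are:
- compound 1 `CC(C)(C)OC(=O)N1CCC[C@H]1C(=O)N1CCC(NS(=O)(=O)c2cc(S(=O)(=O)c3ccccc3)ccc2C(F)(F)F)CC1` gives 25000 nM
- compound 2 `CCNC(=O)N1CCC[C@H]1C(=O)N1CCC(NS(=O)(=O)c2cc(S(=O)(=O)c3ccccc3)ccc2C(F)(F)F)CC1` gives 100000 nM

Of these two, compound 2 stands highest at 100000 nM and its lead over compound 1 lies beyond the usual scatter of repeat measurements. Compound 3 `O=C([C@@H]1CCCN1C(=O)N1CCOCC1)N1CCC(NS(=O)(=O)c2cc(S(=O)(=O)c3ccccc3)ccc2C(F)(F)F)CC1` is still unmeasured. It differs from compound 2 by carrying morpholin-4-yl in place of ethylamino on a carbonyl carbon.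

Among the measured compounds shown here, only one measured step bears on this change, namely ethylamino in place of tert-butoxy on a carbonyl carbon. It is modest and involves a different pair of groups, so it offers a guide to size but not to direction. For the measured compounds named here, no compound with morpholin-4-yl has been measured. Going by a 4.0-fold higher number from compound 1 to compound 2 (0.60 log units; beyond the scatter) as the only guide, a smaller step is expected, perhaps within the scatter and leaning towards a lower number. The expected change is a 1.4-fold lower number from compound 2 to compound 3 (0.15 log units; within the scatter) as the most likely outcome. For compound 3 the estimate is 70000 nM with an expected range from 25000 nM to 180000 nM as its likely span.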

Compound 3, solubility: 50000 nM
Compound 3: middle estimate off by 1.4-fold (0.15 log units), on the high side; low and high end bracket the measured number.
By their numbers in this assay, from the lowest: compounds 1, 3 and 2 (each within the scatter of the next, the first and the last beyond it).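

Putting morpholin-4-yl on this carbonyl carbon gives, in this assay, a 2.0-fold lower number from compound 2 to compound 3 (0.30 log units; within the scatter) when it replaces ethylamino and a 2.0-fold higher number from compound 1 to compound 3 (0.30 log units; within the scatter) when it replaces tert-butoxy. Among the compounds shown here, compound 3 therefore cannot be told apart from either of the earlier compounds in this assay, even though they differ from each other by a 4.0-fold higher number from compound 1 to compound 2 (0.60 log units; beyond the scatter) and even though the change to compound 3 adds a six-membered ring and removes the hydrogen-bond donor of ethylamino. No measurement at hand offers a reason for these readings.

Because compound 3 changes several features at once, the compounds shown leave open whether the ring, its oxygen or the loss of the amide hydrogen matters on its own, and whether these effects cancel or are simply small. Piperidin-1-yl on the same carbonyl carbon would keep the ring without the oxygen and dimethylamino would lack both the ring and the amide hydrogen, so each could help separate these features, while a group carrying a carboxylic acid would test a charged substituent at this position.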